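This account rests on a few compounds, and the source may have more. Where it says the series, first, only, none or still open, it means among the compounds named here.

Measured in a toxicity assay on THP-1 cells (Homo sapiens) for inhibition; on this read-out lower numbers stand for higher toxicity in this test and higher numbers for lower toxicity in this test:
compound 1 `Cn1c(-c2ccccc2)cnc1NC(=O)c1ccc(Cl)cc1`: > 100000 nM (a limit)
compound 2 `COc1ccccc1-c1cnc(NC(=O)c2ncc[nH]2)n1C`: > 50000 nM (a limit)
compound 3 `Cn1c(-c2ccccc2)cnc1NC(=O)c1cccc(Cl)c1`: > 50000 nM (a limit)

Compound 3 has only a limit and no number, and it sits at the limit of > 50000 nM in this assay, at which 2 of the 3 values shown sit. Compound 4 `Cn1c(-c2ccccc2)cnc1NC(=O)c1ncc[nH]1` keeps the core of compound 3 and carries 1H-imidazol-2-yl in place of 3-chlorophenyl on a carbonyl carbon. Among the compounds with values here, the only measured step is a step that the two limits leave unreadable from compound 1 to compound 3, so it offers no size to carry over. Compound 2 already carries 1H-imidazol-2-yl on a carbonyl carbon, and its limit of > 50000 nM is the ground for expecting no readable change in this assay. The estimated step that the limit leaves unreadable from compound 3 to compound 4 is expected to stay within the scatter, with no direction to be claimed. For compound 4 the expected value is 60000 nM, with an estimated range from 25000 nM to 120000 nM, and a report as a limit only is the likeliest outcome.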

Compound 4, half-maximal cytotoxic concentration: > 100000 nM
Compound 4 ended at the assay's limit (the forecaster's own chance of this, stated with the estimate: 85%); middle value at least 1.6-fold (0.22 log units) from the limit.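

Compound 4 gives only a limit, > 100000 nM. Compound 1, compound 2 and compound 3 are also reported as limits, so none of the steps to compound 4 can be read. The compounds shown leave open at what concentration any of them becomes cytotoxic.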